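The compounds below may be only part of what the source reports. "The series", "measured", "known", "first", "only" and "open" are said of these compounds alone.

For the measured compounds named here, compound 2 `CC(C)OC(=O)c1sc(N(COP(=O)(OC(C)(C)C)OC(C)(C)C)c2ncccn2)nc1-c1cnccn1` in a toxicity assay on THLE-2 cells (Homo sapiens) for cytotoxicity, read by MTT assay, with a stated time of 72 h (a higher number here means that more compound is tolerated, a lower number that less compound is tolerated), gives 50000 nM, the highest of the two numbers so far. Its nearest neighbour, compound 1 `CC(C)OC(=O)c1sc(N(COP(=O)(OC(C)(C)C)OC(C)(C)C)c2ncccn2)nc1-c1ccccn1`, gives 42200 nM in this assay, and the step of a 1.2-fold higher number from compound 1 to compound 2 (0.07 log units; within the scatter) is within the scatter. Compound 3 `CC(C)OC(=O)OCN(c1ncccn1)c1nc(-c2cnccn2)c(C(=O)OC(C)C)s1` differs from compound 2 by a group of 6 heavy atoms (4 carbon, 2 oxygen; no ring) in place of a group of 12 heavy atoms (8 carbon, 3 oxygen, 1 phosphorus; no ring), on an oxygen on a saturated carbon. Going by the values given here, no measured step touches this part of the molecule; the only step known, from pyridin-2-yl to pyrazin-2-yl, stays within the scatter. Nothing here gives a direction, so no change beyond the scatter is expected: the estimated step is a 1.3-fold lower number from compound 2 to compound 3 (0.10 log units; within the scatter), and compound 3 is expected to give about 40000 nM in this assay, between 18000 nM and 90000 nM.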

Compound 3, half-maximal cytotoxic concentration: 50000 nM
Compound 3: middle estimate off by 1.3-fold (0.10 log units), on the low side, within the range that was stated.
By their numbers in this assay, from the lowest: compounds 1, 2 and 3 (each within the scatter of the next).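

In this assay, isopropoxycarbonyl in place of the phosphorus-containing group of 12 heavy atoms, on an oxygen on a saturated carbon, gives no change at the digits printed from compound 2 to compound 3 (within the scatter). With pyrazin-2-yl on the shared core, the number read here therefore does not depend on phosphorus at this position. Nothing available explains why the two groups read alike.

Still open, as far as these compounds go, is whether isopropoxycarbonyl reads the same with pyridin-2-yl on the core. Also open, from the compounds shown here alone, is how an acetyl group or a longer carbon chain on this oxygen would read in this assay.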